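A bromo step measured once and expected again

The source may hold more compounds than are shown below. What is called first, only, known or untested is meant among the compounds shown, and "the series" means these compounds.

Compound 1, `O=C1NC[C@@H](c2c[nH]c3ccccc23)N[C@H]1c1c[nH]c2ccccc12`, in this assay: > 10 ug/mL (a limit).
Compound 2, `O=C(C1=NC(c2c[nH]c3ccccc23)CN1)c1c[nH]c2cc(Br)ccc12`, in this assay: > 30 ug/mL (a limit).
Compound 3, `O=C(C1=NC(c2c[nH]c3cc(Br)ccc23)CN1)c1c[nH]c2cc(Br)ccc12`, in this assay: 4.82 ug/mL.

Of the compounds shown here, three have been measured in an ADME assay on SK-MEL-2 cells (Homo sapiens) for cytotoxicity; a lower number here means that less compound is needed, a higher number that more compound is needed for the effect. For compound 1 the result is only a limit, > 10 ug/mL. For compound 2 the result is likewise only a limit, > 30 ug/mL. Compound 3 gives 4.82 ug/mL. Compound 3 differs from compound 2 by bromo in place of hydrogen on an aromatic carbon, and this change brought an at least 6.2-fold lower number from compound 2 to compound 3 (0.79 log units; beyond the scatter). The size of that step is known only as a bound because compound 2 sits at the limit of > 30 ug/mL in this assay, at which 1 of the 3 values shown sits.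

Compound 4, `O=C1NC[C@@H](c2c[nH]c3ccccc23)N[C@H]1c1c[nH]c2cc(Br)ccc12`, has not yet been measured. Among the measured compounds shown here, it differs from compound 1 by bromo in place of hydrogen on an aromatic carbon, the same change as the one between compound 2 and compound 3, set at the same place. The difference between the core of compound 1 and the core of compound 2 is not broken down here. Compound 1 sits at the limit of > 10 ug/mL in this assay, at which 1 of the 3 values shown sits, so the measured step from compound 1 to compound 4 can itself only be a bound.

On the strength of an at least 6.2-fold lower number from compound 2 to compound 3 (0.79 log units; beyond the scatter), a step of an at least 2.0-fold lower number from compound 1 to compound 4 (0.30 log units; that floor lies within the scatter) is expected, the estimate carried over from one core to the other. Compound 4 is accordingly expected to give about 5 ug/mL, most likely between 1.5 ug/mL and 25 ug/mL.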

Compound 4, concentration for half-maximal effect: > 10 ug/mL
Compound 4: a limit, no number; the forecaster's own chance of this, stated with the estimate: 35%; at least 2.0-fold (0.30 log units) between middle value and limit.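

In this assay compound 4 gives > 10 ug/mL, which is a limit and not a number. Compound 1 sits at the same limit, so no size can be read for the bromo step between compound 1 and compound 4: the limit of > 10 ug/mL in this assay, at which 2 of the 4 values shown sit.

As far as these compounds go, whether bromo in place of hydrogen on an aromatic carbon changes the number at all on the core of compound 1 stays open.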